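Dropping the methoxy from compound 1

This account rests on a few compounds, and the source may have more. Where it says the series, first, only, none or still open, it means among the compounds named here.

Measured so far in a functional assay on the whole organism (strain Sprague-Dawley) for inhibition, with Rattus norvegicus as the target; on this read-out higher numbers stand for an effect only at larger amounts of compound and lower numbers for an effect already at smaller amounts:
compound 1 `COc1ccc2c(=O)c(-c3nn[nH]n3)c[nH]c2c1` — compound 1 gives 10 mg/kg
compound 2 `O=c1c(-c2nn[nH]n2)c[nH]c2c(Cl)c(Cl)ccc12` — compound 2 gives > 0.156 mg/kg, a limit of the assay and not a number
compound 3 `O=C(O)c1cnc2ccc(C(F)(F)F)cc2c1` — compound 3 gives > 25 mg/kg, likewise a limit of the assay and not a number

For the measured compounds named here, compound 1 stands as the only measured number in this assay; the other two values are limits, one at the limit of > 0.156 mg/kg in this assay, at which 1 of the 3 values shown sits, and one at the limit of > 25 mg/kg in this assay, at which 1 of the 3 values shown sits. Going by the values given here, no two measured compounds differ in a single place, so no measured step is available to size the effect of a small change on this read-out.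

Compound 4 `O=c1c(-c2nn[nH]n2)c[nH]c2ccccc12` is the unmeasured partner of compound 1. The change is hydrogen in place of methoxy on an aromatic carbon.

Among the compounds with values here, with no measured step of this kind to lean on, the expected step of no change at the digits printed from compound 1 to compound 4 (within the scatter) is taken as lying within the scatter, with the direction left open. In this assay compound 4 is expected to give about 10 mg/kg, plausibly between 3 mg/kg and 40 mg/kg.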

Compound 4, minimum effective dose: 1.25 mg/kg
For compound 4 the middle estimate is 8.0-fold (0.90 log units) above the measured one, outside the stated range (below it).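

For the compounds shown here, the first measured single-place step in this assay is an 8.0-fold lower number from compound 1 to compound 4 (0.90 log units; beyond the scatter), with hydrogen in place of methoxy on an aromatic carbon. Going by these compounds alone, the methoxy at this place is therefore not required for an effect on this read-out, and compound 4 reaches it at a smaller dose than compound 1, something the earlier compounds, none of which differed in a single place, could not show. No measured property among the data shown bears on this step.

Whether any substituent at this place costs dose, or only the methoxy does, remains open, as no value is shown here for a hydroxyl, an amine or a fluorine. Also open, on these data alone, is whether the same change would give a step of similar size on a core carrying other substituents.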